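Replacing 2-chlorophenyl with (3-chlorophenyl)carbonyl in compound 1

The compounds below may be only part of what the source reports. "The series", "measured", "known", "first", "only" and "open" are said of these compounds alone.

Measured so far in a functional assay on SGC-7901 cells (Homo sapiens) for antiproliferative activity, read by MTT assay, with a stated time of 24 h (a higher number here means a weaker inhibitor, a lower number a stronger inhibitor), by antiproliferative potency

- Compound 1 `O=C(NNc1ccccc1Cl)c1ccc(NS(=O)(=O)c2cnc(O)nc2O)cc1` gives 3630 nM
- Compound 2 `O=C(NNc1cccc(Cl)c1)c1cccc(NS(=O)(=O)c2cnc(O)nc2O)c1` gives 11800 nM
- Compound 3 `O=C(NNc1ccccc1F)c1ccccc1NS(=O)(=O)c1cnc(O)nc1O` gives > 20000 nM

Compound 1 (3630 nM) holds the lowest of the two actual numbers. Compound 2 (11800 nM) gives a higher number, and the gap lies beyond the scatter of repeated measurements. Compound 3 gives (> 20000 nM), which is a limit of the assay and not a number.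

The next compound to be tested is compound 4 (`O=C(NNC(=O)c1cccc(Cl)c1)c1ccc(NS(=O)(=O)c2cnc(O)nc2O)cc1`). It carries (3-chlorophenyl)carbonyl in place of 2-chlorophenyl on an amine nitrogen. Within the data shown here, no measured pair of compounds isolates this change, so the expectation rests on thin ground. Compound 1 (3630 nM) already has the lowest number of the three, so a change away from it is expected to lose rather than gain activity in this assay. A modest weakening, just beyond the scatter, is the expected outcome (a 2.5-fold higher number from compound 1 to compound 4 (0.39 log units; beyond the scatter)). The estimate for compound 4 is 9000 nM (expected range 3000 nM to 20000 nM).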

Compound 4, half-maximal inhibitory concentration: 8610 nM
Compound 4: middle estimate off by 1.0-fold (0.02 log units), on the high side; the measured number falls inside the stated range.
By their numbers in this assay, from the lowest: compound 1; then compounds 4 and 2 (each within the scatter of the next). At a limit, above all of these: compound 3.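

Among these compounds, exchanging 2-chlorophenyl for (3-chlorophenyl)carbonyl on an amine nitrogen gives, in this assay, a 2.4-fold higher number from compound 1 to compound 4 (0.38 log units; beyond the scatter), a modest step that gives the first reading of a change in one place, which the earlier compounds could not provide. The step carries two differences at once, since the entering group brings a carbonyl and a hydrogen-bond acceptor that the leaving group lacks, while its chlorine is also numbered differently on the ring, and this single pair cannot separate the two. Nothing among the measurements shown accounts for the size of this step.

Going by these compounds, it remains open how much of the step belongs to the carbonyl and how much to the chlorine, which a (2-chlorophenyl)carbonyl group or an unsubstituted benzoyl group on the same nitrogen would help to divide. On these data alone, it is also open whether an acetyl group or a longer alkyl chain at this place would keep a measurable number, and whether the same exchange would give a step of similar size on a different core.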